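The compounds below may be only part of what the source reports. "The series", "measured", "known", "first", "only" and "open" are said of these compounds alone.

The series shares one core; compound 1 `CCOc1ccccc1-c1ccc(-c2nc3cnccc3c(NC(C)C(=O)O)c2C#N)cc1` carries a (1-carboxyethyl)amino group on it. Among the measured compounds shown here, in a physicochemical assay for lipophilicity, read by HPLC, at pH 7.5 (a lower number here means a more polar compound, a higher number a more lipophilic compound), compound 1 gives 2.1, the lowest of the two numbers so far. Compound 2 `CC[C@@H](Nc1c(C#N)c(-c2ccc(-c3cccc(Cl)c3)cc2)nc2cnccc12)C(N)=O` differs from compound 1 in several places, so of this pair only the two values themselves can be read; in this assay compound 2 gives 3.1, a number one full unit higher and beyond the scatter. Compound 3 `CCOc1ccccc1-c1ccc(-c2nc3cnccc3c(N[C@H](CC)C(=O)N(C)C)c2C#N)cc1` is the next compound to be measured in this assay. It differs from compound 1 in one place: 1-(dimethylcarbamoyl)propyl in place of 1-carboxyethyl on a nitrogen on an aromatic ring. The group that leaves holds 1 hydrogen-bond donor and 2 oxygen atoms on 5 heavy atoms; the group that enters holds no hydrogen-bond donor on 8 heavy atoms, with 1 defined stereocentre. A sizeable step upward is expected here, an estimated shift of a number 1.60 log units higher from compound 1 to compound 3 (beyond the scatter). Compound 2, which carries a carbamoyl group, already gives 3.1 in this assay. For compound 3 the expected value in this assay is 3.7, with a range of 3.1 to 4.3.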

Compound 3, distribution coefficient: 3.7
Estimate against measurement, compound 3: no gap at the digits printed; low and high end bracket the measured number.
By their numbers in this assay, from the lowest: compound 1; then compound 2; then compound 3.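

In this assay, among the compounds shown here, the first comparison that differs in one place shows that this position alone can carry a large change: 1-(dimethylcarbamoyl)propyl in place of 1-carboxyethyl on a nitrogen on an aromatic ring gives a number 1.60 log units higher from compound 1 to compound 3 (beyond the scatter). The exchange alters the end group and the chain at once, and also brings in a defined stereocentre, so the step belongs to the whole exchange and cannot be divided among these parts, while the steps to compound 2 cannot be read because it differs from both other compounds in several places. No measurement shown here bears on the cause of this step.

The compounds shown leave open how much of the step follows the end group and how much follows the chain, which 1-(dimethylcarbamoyl)ethyl or 1-carboxypropyl on the same nitrogen would begin to separate. Also open, on these data alone, is how a methyl ester or a primary amide on this chain would read in this assay with the rest of compound 1 held constant.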